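This account rests on a few compounds, and the source may have more. Where it says the series, first, only, none or still open, it means among the compounds named here.

Measured compounds and their results:

- compound 1 `Clc1ccc(COc2ccc(/C=C/C(/C=C/c3ccccn3)=N/Oc3ncnc4ccccc34)cc2)cc1`, which in a functional assay on SMMC-7721 cells (Homo sapiens) for inhibition, read by MTT assay, with a stated time of 72 h, tested at 10 uM (a lower number here means a weaker effect, a higher number a stronger effect of the compound at the concentration tested), gives 94.4%
- compound 2 `Clc1ccc(COc2ccc(/C=C/C(/C=C/c3ccccn3)=N/Oc3ncnc4cc(Cl)ccc34)cc2)cc1`, which in this assay gives 88.1%
- compound 3 `Clc1ccc(COc2ccc(/C=C/C(/C=C/c3cccs3)=N/Oc3ncnc4ccccc34)cc2)cc1`, which in this assay gives 97.5%

All three share the same core and all three reach high inhibition at the tested concentration. Compound 1 stands second of the three numbers, but its steps to both neighbours lie within the scatter: a number 3.1 percentage points higher from compound 1 to compound 3 (within the scatter) and a number 6.3 percentage points lower from compound 1 to compound 2 (within the scatter). Neither the chloro added to the core nor the exchange of the ring on the chain moved the read-out beyond what repeat measurements would show.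

Compound 4 `Clc1ccccc1COc1ccc(/C=C/C(/C=C/c2ccccn2)=N/Oc2ncnc3ccccc23)cc1` differs from compound 1 in one place: 2-chlorophenyl in place of 4-chlorophenyl on a saturated chain carbon bound to an oxygen on an aromatic ring. Going by the values given here, no measured step touches the chlorophenyl group on the saturated chain carbon bound to an oxygen on an aromatic ring, so there is nothing direct to lean on. What the measured steps do show is that two separate single changes to this scaffold each stayed within the scatter, and the same outcome is expected here, with a step of a number 4.4 percentage points lower from compound 1 to compound 4 (within the scatter). Compound 4 is therefore estimated at 90%, within a range from 75% to 98%.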

Compound 4, a percentage reported as inhibition, at one concentration (the size of the read-out at that concentration, not a potency): 96.9%
Compound 4: the middle estimate sits 6.9 percentage points below what was measured; the range from low to high includes it.
By their numbers in this assay, from the lowest: compounds 2, 1, 4 and 3 (each within the scatter of the next).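

In this assay, going by these compounds alone, placing 2-chlorophenyl in place of 4-chlorophenyl on the saturated chain carbon bound to an oxygen on an aromatic ring gives a number 2.5 percentage points higher from compound 1 to compound 4 (within the scatter) and so extends the picture to a part of the molecule that the earlier steps left untouched. The two groups hold the same atoms, so the change concerns only where the chlorine sits on the ring, and this read-out does not separate the two arrangements. Nothing available here explains this result. 

Going by these compounds, it remains open whether a methoxy group, a trifluoromethyl group or an amine in place of the chlorine, or a plain phenyl without it, would keep inhibition as high. On these data alone, how these compounds compare in potency also remains open: the read-out comes from one concentration only.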